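The source may hold more compounds than are shown below. What is called first, only, known or untested is meant among the compounds shown, and "the series" means these compounds.

Measured compounds:
Compound 1, `Cc1noc(NS(=O)(=O)c2ccc(NC(=O)c3cc4ccccc4oc3=O)cc2)c1C`: in a functional assay on HepG2 cells (Homo sapiens) for antiproliferative activity, read by fluorescence and resazurin assay, with a stated time of 48 h (on this read-out lower numbers stand for stronger inhibition and higher numbers for weaker inhibition), compound 1 gives 24000 nM.
Compound 2, `Cc1noc(NS(=O)(=O)c2ccc(NC(=O)c3cc4cc([N+](=O)[O-])ccc4oc3=O)cc2)c1C`: in this assay compound 2 gives 15000 nM.
Compound 3, `CCOc1ccc(NC(=O)c2cc3cc([N+](=O)[O-])ccc3oc2=O)cc1`: in this assay compound 3 gives 28300 nM.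

Compound 1 differs from compound 2 by hydrogen in place of nitro on an aromatic carbon, and this step gave a 1.6-fold higher number from compound 2 to compound 1 (0.20 log units; within the scatter). The two cores differ by ethoxy in place of (3,4-dimethyl-1,2-oxazol-5-yl)sulfamoyl on an aromatic carbon, a step that gave a 1.9-fold higher number from compound 2 to compound 3 (0.28 log units; within the scatter). Compound 4, `CCOc1ccc(NC(=O)c2cc3ccccc3oc2=O)cc1`, has not yet been measured; it differs from compound 3 by hydrogen in place of nitro on an aromatic carbon, the same change as from compound 2 to compound 1, at a place described in the same words. The step is expected to be a 1.4-fold higher number from compound 3 to compound 4 (0.15 log units; within the scatter), resting on compound 2 and compound 1, because a 1.6-fold higher number from compound 2 to compound 1 (0.20 log units; within the scatter) stayed within the scatter. Compound 4 is therefore expected to give 40000 nM in this assay, with a likely range from 15000 nM to 110000 nM.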

Compound 4, half-maximal inhibitory concentration: 10400 nM
The estimate for compound 4 lay 3.8-fold (0.59 log units) above the measured number; the whole stated range lies above it.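

In this assay, the change to hydrogen in place of nitro did not carry over as a fixed step from one core to the other, since a 2.7-fold lower number from compound 3 to compound 4 (0.43 log units; beyond the scatter) sets it apart from the earlier pair: the same change on two cores in this assay, a 1.6-fold higher number (0.20 log units; within the scatter) from compound 2 to compound 1 and a 2.7-fold lower number (0.43 log units; beyond the scatter) from compound 3 to compound 4, 4.4-fold (0.64 log units) apart, beyond the scatter of two such steps

On the core with ethoxy the change goes with stronger inhibition, whereas on the core with (3,4-dimethyl-1,2-oxazol-5-yl)sulfamoyl it stays within the scatter. These two pairs show that the outcome of this change depends on the core, but they do not show why, and they give no rule for any third core.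

The compounds shown leave open how the same change behaves with an amine, a carboxylic acid or a longer alkoxy chain in the place of ethoxy. They also leave open whether a halogen or a methoxy group in the place of nitro would follow either pair.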